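This account rests on a few compounds, and the source may have more. Where it says the series, first, only, none or still open, it means among the compounds named here.

Measured so far:
- compound 1, `Cc1cccc(Cc2cc(C)ccc2OCCn2ccc(=O)[nH]c2=O)c1`: 199000 nM
- compound 2, `Cc1cc(C)cc(C(=O)c2cc(Cl)ccc2OCCn2ccc(=O)[nH]c2=O)c1`: 16600 nM

In a physicochemical assay for solubility (a higher number here means a more soluble compound, a lower number a less soluble compound), compound 1 gives 199000 nM and stands at the higher of the two numbers; compound 2 gives 16600 nM, a gap that lies beyond the usual scatter. The two compounds differ in more than one place, so no single step can be read from that gap.

Compound 3, `Cc1cc(C)cc(Cc2cc(C)ccc2OCCn2ccc(=O)[nH]c2=O)c1`, has not yet been measured. It differs from compound 1 in one place: methyl in place of hydrogen on an aromatic carbon. Seen one bond further out, a 3-methylbenzyl group becomes a 3,5-dimethylbenzyl group, while the rest of the shared core is unchanged.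

Among the compounds with values here, no measured pair shows what this change does here. The expected step from compound 1 to compound 3 is a 1.8-fold lower number from compound 1 to compound 3 (0.26 log units; within the scatter), a small move downward that may not reach beyond the scatter. Compound 3 is therefore expected to give about 110000 nM, within a range from 45000 nM to 260000 nM.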

Compound 3, solubility: 185000 nM
Estimate against measurement, compound 3: 1.7-fold (0.23 log units) below; low and high end bracket the measured number.
By their numbers in this assay, from the lowest: compound 2; then compounds 3 and 1 (each within the scatter of the next).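

Going from a 3-methylbenzyl to a 3,5-dimethylbenzyl group, with the methyl placed on an aromatic carbon, gives a 1.1-fold lower number from compound 1 to compound 3 (0.03 log units; within the scatter) in this assay and so leaves compound 1 and compound 3 indistinguishable. Within the data shown here, this is the first direct reading of this position, and it shows that, in this one case, a second methyl on the ring can be carried with no measurable difference in this read-out. Nothing measured for these compounds bears on the reason for this result.

As far as these compounds go, this single step covers only methyl, so it remains open whether a larger or very different group at this place, such as an amine or a carboxylic acid, would also leave the number unmoved. Compound 2 differs from compound 3 in more than one place, so the compounds shown cannot tie its number to any one of those differences.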